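The source may report more compounds than this note shows. Statements on the series, on what has been measured and on what is new or still open speak of the compounds shown alone.

Measured so far in an ADME assay on HepG2 cells (Homo sapiens) for cytotoxicity (a lower number here means that less compound is tolerated, a higher number that more compound is tolerated), all three values being limits:
- compound 1 `CN(C)CC#Cc1cc2ncnc(Nc3ccc(OCc4cccc(F)c4)c(Cl)c3)c2s1`: > 32 uM
- compound 2 `Fc1cccc(COc2ccc(Nc3ncnc4cc(C#CCN5CCNCC5)sc34)cc2Cl)c1`: > 29 uM
- compound 3 `CC(C)(C)OC(=O)N1CCN(CC#Cc2cc3ncnc(Nc4ccc(OCc5cccc(F)c5)c(Cl)c4)c3s2)CC1`: > 24 uM

Compound 2 has only a limit, > 29 uM, and no number. Compound 4 `CC(C)CC#Cc1cc2ncnc(Nc3ccc(OCc4cccc(F)c4)c(Cl)c3)c2s1` differs from it by isopropyl in place of piperazin-1-yl on a saturated chain carbon bound to a triple-bonded carbon. Among the measured compounds shown here, two measured steps bear on this change, and neither has a readable size: a step that the two limits leave unreadable from compound 1 to compound 2 and a step that the two limits leave unreadable from compound 2 to compound 3. The first of these changes the same place. Compound 1, with dimethylamino there, also gives only a limit, > 32 uM. No step beyond the scatter is therefore expected in this assay, and no direction is expected. The expected step is a step that the limit leaves unreadable from compound 2 to compound 4. For compound 4 the estimated value is 30 uM, with an expected range of 12 uM to 45 uM.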

Compound 4, half-maximal toxic concentration: > 32 uM
Compound 4 was reported as a limit (the forecaster's own chance of this, stated with the estimate: 70%); middle value at least 1.0-fold (0.02 log units) away from the limit.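

Compound 4, like compound 1 and compound 2, gives only a limit in this assay, so neither new step can be read. The compounds shown leave open whether the group on the saturated chain carbon changes cytotoxicity at all.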